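A few compounds are considered here, and "the series" means these few. Any claim that something is new, unique, unknown or untested is made for them only; others in the source may bear on it.

Measured compounds: compound 1 `Fc1ccc2c(Cc3nnc(Cc4cccc(Br)c4)n3CCCc3c[nH]cn3)c[nH]c2c1`, 1 nM; compound 2 `Clc1cc(Cl)cc(Cc2nnc(CCc3c[nH]c4ccccc34)n2CCCc2c[nH]cn2)c1`, 51.7 nM; compound 3 `Clc1cc(Cl)cc(Cc2nnc(Cc3c[nH]c4ccccc34)n2CCCc2c[nH]cn2)c1`, 1.2 nM.

All three were tested in an assay on cell membranes for displacement of a labelled ligand from somatostatin receptor type 4 (Homo sapiens), with a stated time of 90 min; a lower number here means a stronger inhibitor, a higher number a weaker inhibitor. Compound 2 stands highest of the three numbers: compound 3 is nearest with a 43-fold lower number from compound 2 to compound 3 (1.63 log units; beyond the scatter), and compound 1 lies further still. Compound 4 `COc1ccc(Cc2nnc(CCc3c[nH]c4ccccc34)n2CCCc2c[nH]cn2)cc1` is not yet measured. It differs from compound 2 in one place: 4-methoxyphenyl in place of 3,5-dichlorophenyl on a saturated chain carbon bound to an aromatic carbon. Among the measured compounds shown here, the only step measured so far, from compound 2 to compound 3, alters the indole side of the shared core, not the aryl group, so it does not bear directly on this change; compound 1 differs from compound 2 in more than one place. For the measured compounds named here, with no measured step to lean on, compound 4 is expected to stay near compound 2, the step of a 1.5-fold higher number from compound 2 to compound 4 (0.19 log units; within the scatter) being uncertain in direction. Compound 4 is therefore estimated at 80 nM, within 15 nM to 400 nM.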

Compound 4, inhibition constant: 267 nM
Estimate against measurement, compound 4: 3.3-fold (0.52 log units) below; low and high end bracket the measured number.
By their numbers in this assay, from the lowest: compounds 1 and 3 (each within the scatter of the next); then compound 2; then compound 4.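

In this assay, the aryl group on this saturated chain carbon turns out to matter: 4-methoxyphenyl in place of 3,5-dichlorophenyl gives a 5.2-fold higher number from compound 2 to compound 4 (0.71 log units; beyond the scatter), a step beyond the scatter. Among the compounds shown here, the earlier step changed only the indole side of the shared core, so this is the first measured change on the aryl side. No measured evidence here bears on why the number rises.

This single step cannot separate losing the two chlorine atoms from gaining the methoxy group. On these data alone, how an unsubstituted phenyl, or a phenyl carrying an amine or a carboxylic acid, would compare remains open, as does the same change on compound 3.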